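Shortening the Side Chain: Cytotoxicity in Cultured Cells

The source may report more compounds than this note shows. Statements on the series, on what has been measured and on what is new or still open speak of the compounds shown alone.

compound 1 `CCCCCCCCCCCCCC(=O)c1c(O)cc(C)oc1=O`: > 200000 nM
compound 2 `CCCCCCCCCCCCCCCC(=O)c1c(O)cc(C)oc1=O`: 165000 nM
compound 3 `CCCCCCCCCCCCCCc1c(O)cc(C)oc1=O`: 24100 nM

All three were tested in an ADME assay on L929 cells (Mus musculus, culture collection number NCTC 929) for cytotoxicity, read by MTT assay, with a stated time of 72 h; on this read-out lower numbers stand for stronger inhibition and higher numbers for weaker inhibition. Compound 2 gives 165000 nM. For compound 1 the result is a limit of the assay, > 200000 nM, noted as the limit of > 200000 nM in this assay, at which 1 of the 3 values shown sits. Compound 2 and compound 1 differ by hydrogen in place of ethyl on a saturated chain carbon, ten or more bonds along the chain from a carbonyl carbon. That change made a step of an at least 1.2-fold higher number from compound 2 to compound 1 (0.08 log units; that floor lies within the scatter). Compound 3 gives 24100 nM in this assay; how its core differs from the core of compound 2 is not broken down here.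

Compound 4 `CCCCCCCCCCCCc1c(O)cc(C)oc1=O` is not yet measured. It differs from compound 3 by hydrogen in place of ethyl on a saturated chain carbon, ten or more bonds along the chain from an aromatic carbon, the same kind of change as between compound 2 and compound 1, though here the chain is counted from an aromatic carbon rather than from a carbonyl carbon. Because the earlier step of an at least 1.2-fold higher number from compound 2 to compound 1 (0.08 log units; that floor lies within the scatter) stayed small, compound 4 is expected to give 35000 nM in this assay. The expected step is a 1.5-fold higher number from compound 3 to compound 4 (0.16 log units; within the scatter). For compound 4 the expected range runs from 15000 nM to 90000 nM.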

Compound 4, half-maximal inhibitory concentration: 57200 nM
Compound 4: middle estimate off by 1.6-fold (0.21 log units), on the low side, and the stated range covers the measured number.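

In this assay, hydrogen in place of ethyl on a saturated chain carbon, ten or more bonds along the chain from an aromatic carbon, gives a 2.4-fold higher number from compound 3 to compound 4 (0.38 log units; beyond the scatter). Set beside the earlier case, the same change reads as follows on the two cores: the same change on two cores in this assay, an at least 1.2-fold higher number (0.08 log units; that floor lies within the scatter) from compound 2 to compound 1 and a 2.4-fold higher number (0.38 log units; beyond the scatter) from compound 3 to compound 4; the limit leaves it open whether they differ. The result for compound 1 is a limit and not a number, so the series shows a measured size for this change on the core of compound 3 only, and does not show that this size carries over to the core of compound 2: the limit of > 200000 nM in this assay, at which 1 of the 4 values shown sits.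

The compounds shown leave open how the number would move with a still shorter or a longer chain on the core of compound 3. They also leave open how a chain carrying an amine or a carboxylic acid would read in this assay.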